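Saturating the vinyl nitrile: what it may cost in clearance

A few compounds are considered here, and "the series" means these few. Any claim that something is new, unique, unknown or untested is made for them only; others in the source may bear on it.

Measured so far:
- compound 1, `COC(=O)c1cc(N)c(Nc2ccc(C#N)cc2)cc1Oc1c(C)cc(/C=C/C#N)cc1C`: 20 mL.min-1.g-1
- compound 2, `CNC(=O)c1cc(N)c(Nc2ccc(C#N)cc2)cc1Oc1c(C)cc(CCC#N)cc1C`: 120 mL.min-1.g-1

Both compounds were tested in an in vitro ADME assay on microsomes from liver (Homo sapiens) for metabolic stability, tested at 1 uM; a lower number here means slower removal, a higher number faster removal of the compound. Compound 1 gives 20 mL.min-1.g-1. Compound 2 gives 120 mL.min-1.g-1, the higher of the two numbers; the gap to compound 1 is beyond the usual scatter of this assay. The two compounds differ in two places at once, so what either change alone does to the number cannot be read from them.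

Compound 3, `CNC(=O)c1cc(N)c(Nc2ccc(C#N)cc2)cc1Oc1c(C)cc(/C=C/C#N)cc1C`, has not yet been measured. It differs from compound 2 in one place only: 2-cyanoethenyl in place of 2-cyanoethyl on an aromatic carbon. Going by the values given here, the group that enters is the one compound 1 carries at that same spot, while the rest of compound 3 matches compound 2.

Among the compounds with values here, with no single-change step available, the expectation rests on the two values alone. Within the data shown here, since compound 1, the only compound carrying 2-cyanoethenyl, gives 20 mL.min-1.g-1, a step downward is expected, a 2.4-fold lower number from compound 2 to compound 3 (0.38 log units; beyond the scatter), though its size is uncertain. Compound 3 is estimated at 50 mL.min-1.g-1, with a range from 20 mL.min-1.g-1 to 130 mL.min-1.g-1.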

Compound 3, intrinsic clearance in microsomes: 150 mL.min-1.g-1
The estimate for compound 3 lay 3.0-fold (0.48 log units) below the measured number, outside the stated range (above it).
By their numbers in this assay, from the lowest: compound 1; then compounds 2 and 3 (each within the scatter of the next).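

In this assay, placing 2-cyanoethenyl where 2-cyanoethyl stood on the aromatic carbon gives a 1.3-fold higher number from compound 2 to compound 3 (0.10 log units; within the scatter) and so, with the methylamino group on the carbonyl carbon, the double bond in this chain makes no difference that this read-out can resolve. The step that stands out lies at the other place, where methylamino in place of methoxy on a carbonyl carbon gives a 7.5-fold higher number from compound 1 to compound 3 (0.88 log units; beyond the scatter) with 2-cyanoethenyl held the same, so among these compounds the clear change in the number comes with the carbonyl substituent and not with the chain. No measurement shown here accounts for either step.

The compounds shown leave open whether 2-cyanoethyl and 2-cyanoethenyl would also read alike with methoxy on the carbonyl carbon, since only one of these two chains appears alongside methoxy. They also leave open how an ethylamino group or a hydroxyl on that carbonyl carbon, or a longer chain ending in a nitrile on the aromatic carbon, would read in this assay against these values.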